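The compounds below may be only part of what the source reports. "The series", "measured", "known", "first", "only" and "open" are said of these compounds alone.

Compound 1 `COc1cc(/C=C/C(=O)c2cccc(-n3cc(-c4ccccc4)[nH]c3=O)c2)ccc1O` gives 2070 nM in a functional assay on SF-268 cells (Homo sapiens) for inhibition; a higher number here means a weaker inhibitor of growth, a lower number a stronger inhibitor of growth.
Compound 2 `COc1cc(/C=C/C(=O)c2cccc(-n3cc(-c4ccccc4)[nH]c3=O)c2)cc(OC)c1OC` gives 1920 nM in this assay.

Compound 2 stands at the lowest of these two numbers, yet compound 1 lies so close that the difference is within the scatter, so no real gap separates them. Compound 3 `COc1ccc(-c2cn(-c3cccc(C(=O)/C=C/c4cc(OC)c(OC)c(OC)c4)c3)c(=O)[nH]2)cc1` has not yet been measured. It differs from compound 2 by methoxy in place of hydrogen on an aromatic carbon. For the measured compounds named here, no measured pair shows this change, so only a small step in this assay is expected, in no clear direction beyond the scatter. Compound 3 is therefore expected to give about 1700 nM, likely between 700 nM and 4200 nM. This estimate means a step of a 1.1-fold lower number from compound 2 to compound 3 (0.05 log units; within the scatter).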

Compound 3, concentration for 50% growth inhibition: 3210 nM
Estimate against measurement, compound 3: 1.9-fold (0.28 log units) below; the measured number falls inside the stated range.
By their numbers in this assay, from the lowest: compounds 2, 1 and 3 (each within the scatter of the next).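

Replacing hydrogen with methoxy on the phenyl group, para to a large group, gives a 1.7-fold higher number from compound 2 to compound 3 (0.22 log units; within the scatter) in this assay. For the compounds shown here, this is the first look at this position, and the change from phenyl to 4-methoxyphenyl cannot be told apart from the scatter, so the added group is tolerated here. No outside measurement bears on this result.

Going by these compounds, whether an amine or a carboxylic acid at this position would shift the number beyond the scatter remains open. So does the effect of a longer chain, such as butoxy, in place of methoxy.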